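The source may report more compounds than this note shows. Statements on the series, on what has been measured and on what is new or still open speak of the compounds shown alone.

Measured in an ADME assay on MT4 cells (Homo sapiens) for cytotoxicity, read by MTT assay, with a stated time of 96 h; a lower number here means that less compound is tolerated, a higher number that more compound is tolerated:
- compound 1 `COc1ccc(-c2nc3cc(C(C)O)ccc3[nH]2)c(OC)c1`: >= 100000 nM (a limit of the assay, not a number)
- compound 2 `COc1ccc(-c2nc3cc(/C(C)=N/NC(N)=O)ccc3[nH]2)c(OC)c1`: 21000 nM
- compound 3 `COc1ccc(-c2nc3cc(/C(C)=N/NC(N)=S)ccc3[nH]2)c(OC)c1`: 72000 nM

Compound 3 holds the higher of the two true numbers, as shown by a 3.4-fold higher number from compound 2 to compound 3 (0.54 log units; beyond the scatter). Compound 1 gives only a limit.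

Compound 4 `COc1ccc(-c2nc3cc(/C(C)=N/NC(N)=S)ccc3n2C2CCCCC2)c(OC)c1` differs from compound 3 as follows: cyclohexyl in place of hydrogen on an aromatic nitrogen. Here, cyclohexyl stands in place of hydrogen on an aromatic nitrogen.

Among the compounds with values here, no measured step touches this nitrogen, so the size of the step can only be gauged from changes made elsewhere. Those are an at least 4.7-fold lower number from compound 1 to compound 2 (0.67 log units; beyond the scatter), an at least 1.3-fold lower number from compound 1 to compound 3 (0.14 log units; that floor lies within the scatter) and a 3.4-fold higher number from compound 2 to compound 3 (0.54 log units; beyond the scatter). The first shows a larger group going with a lower number, while the floor of the second stays within the scatter and does not support that trend. A modest step is therefore a working guess, and its direction is uncertain, though a lower number is favoured.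

The change expected is a 2.9-fold lower number from compound 3 to compound 4 (0.46 log units; beyond the scatter). For compound 4 the estimated value in this assay is 25000 nM, with an expected range from 7000 nM to 85000 nM.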

Compound 4, half-maximal cytotoxic concentration: 17000 nM
Compound 4: middle estimate off by 1.5-fold (0.17 log units), on the high side; low and high end bracket the measured number.
By their numbers in this assay, from the lowest: compounds 4 and 2 (each within the scatter of the next); then compound 3. At a limit, above all of these: compound 1.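

In this assay cyclohexyl in place of hydrogen on the aromatic nitrogen gives a 4.2-fold lower number from compound 3 to compound 4 (0.63 log units; beyond the scatter). Within the data shown here, this is the first measured step at this nitrogen, and it shows that the position is not silent in this read-out: with the rest of compound 3 unchanged, filling the site with a six-membered carbon ring leaves less compound tolerated. Nothing at hand accounts for the size or direction of this step.

As far as these compounds go, whether the step follows the size of the group stays open, and methyl, a longer chain such as butyl, or a cyclohexyl ring bearing an amine at this nitrogen would test that. Also open, from the compounds shown here alone, is whether cyclohexyl gives a similar step on compound 2, which carries oxygen in place of sulfur.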